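Methyl on the saturated ring carbon: second occurrence

The source may report more compounds than this note shows. Statements on the series, on what has been measured and on what is new or still open speak of the compounds shown alone.

Compound 1 `O=C1NCCN(c2cccc(Cl)c2)N1` gives 5300 nM in an assay on RBL-1 cells for inhibition of Polyunsaturated fatty acid 5-lipoxygenase (Rattus norvegicus); on this read-out lower numbers stand for stronger inhibition and higher numbers for weaker inhibition. Compound 2 `CC1CN(c2cccc(Cl)c2)NC(=O)N1`, which carries methyl in place of hydrogen on a saturated ring carbon, gives 2700 nM in this assay, a step of a 2.0-fold lower number from compound 1 to compound 2 (0.29 log units; within the scatter). Compound 3 `O=C1NCCN(c2cccc(Cl)n2)N1` gives 5600 nM in this assay; the difference between its core and the core of compound 1 is not broken down here, and the two values lie within the scatter of each other. Compound 4 `CC1CN(c2cccc(Cl)n2)NC(=O)N1` is the not yet measured partner of compound 3 with the same change, (methyl in place of hydrogen on a saturated ring carbon), at the same place as before. Because the earlier step of a 2.0-fold lower number from compound 1 to compound 2 (0.29 log units; within the scatter) stayed within the scatter, compound 4 is expected to sit near compound 3, with an estimated step of a 1.9-fold lower number from compound 3 to compound 4 (0.29 log units; within the scatter). The estimate for compound 4 in this assay is 2900 nM, between 1300 nM and 6500 nM.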

Compound 4, half-maximal inhibitory concentration: 3500 nM
For compound 4 the middle estimate is 1.2-fold (0.08 log units) below the measured one; the range from low to high includes it.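

In this assay, going by these compounds alone, methyl in place of hydrogen on a saturated ring carbon gives a 1.6-fold lower number from compound 3 to compound 4 (0.20 log units; within the scatter), and the two cores show no difference in this step: the same change on two cores in this assay, a 2.0-fold lower number (0.29 log units; within the scatter) from compound 1 to compound 2 and a 1.6-fold lower number (0.20 log units; within the scatter) from compound 3 to compound 4, 1.2-fold (0.09 log units) apart, within the scatter of two such steps. Both steps lie within the scatter, so the agreement shows only that the methyl is tolerated on both cores, not that it brings a real gain on either. Two cores are also too few to support a rule for the whole series.

The compounds shown leave open whether a longer chain such as ethyl on the same ring carbon would give a step beyond the scatter. The same question stands for an amine or a carboxylic acid there.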